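A few compounds are considered here, and "the series" means these few. Any claim that something is new, unique, unknown or untested is made for them only; others in the source may bear on it.

Measured so far in a functional assay on A549 cells (Homo sapiens) for antiproliferative activity, read by MTT assay, with a stated time of 48 h; a higher number here means a weaker inhibitor, a lower number a stronger inhibitor:
- compound 1 `C/C(=C\CC/C(C)=C/CC[C@@H]1[C@@]2(C)CCC(=O)C(C)(C)[C@H]2CC[C@@]1(C)O)CC/C=C(\C)C(=O)OCc1cn(-c2cccc([N+](=O)[O-])c2)nn1`: > 150000 nM
- compound 2 `C/C(=C\CC/C(C)=C/CC[C@@H]1[C@@]2(C)CCC(=O)C(C)(C)[C@H]2CC[C@@]1(C)O)CC/C=C(\C)C(=O)OCc1cn(-c2cccc(Br)c2)nn1`: > 150000 nM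
- compound 3 `C/C(=C\CC/C(C)=C/CC[C@@H]1[C@@]2(C)CCC(=O)C(C)(C)[C@H]2CC[C@@]1(C)O)CC/C=C(\C)C(=O)OCc1cn(-c2ccc(Br)cc2)nn1`: > 150000 nM

All three entries are limits of the assay, not numbers. Compound 3 has no number of its own and stands at the limit > 150000 nM. The whole series shares this position, as the limit of > 150000 nM in this assay, at which 3 of the 3 values shown sit, records.

The next compound is compound 4 `C/C(=C\CC/C(C)=C/CC[C@@H]1[C@@]2(C)CCC(=O)C(C)(C)[C@H]2CC[C@@]1(C)O)CC/C=C(\C)C(=O)OCc1cn(-c2ccccc2F)nn1`. The difference is 2-fluorophenyl in place of 4-bromophenyl on an aromatic nitrogen of the five-membered aromatic ring with 3 nitrogen.

The measured steps that bear on this change also alter the aryl group: a step that the two limits leave unreadable from compound 2 to compound 3, a step that the two limits leave unreadable from compound 1 to compound 3 and a step that the two limits leave unreadable from compound 1 to compound 2. None of them has a readable size, so no measured size or direction carries over to compound 4. For the measured compounds named here, no fluorinated aryl compound has been measured yet.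

The expectation rests on compound 1, compound 2 and compound 3 all sitting at the limit of > 150000 nM in this assay, at which 3 of the 3 values shown sit. Compound 4 is therefore expected to lie near that limit and may well be reported only as a limit. The expected step is a number no higher from compound 3 to compound 4 (the limit leaves the size open). The estimate for compound 4 is 150000 nM. The estimated range for compound 4 runs from 70000 nM to 300000 nM.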

Compound 4, half-maximal inhibitory concentration: > 150000 nM
Compound 4: no number, only a limit (the forecaster's own chance of this, stated with the estimate: 80%); the middle value lies on the limit itself.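

Compound 4 gives a limit and not a number, as do compound 1, compound 2 and compound 3, so no step among these compounds can be read: the limit of > 150000 nM in this assay, at which 4 of the 4 values shown sit.

The compounds shown leave open how the four aryl groups rank against one another, and whether any aryl group on the shared core gives a number rather than a limit.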